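Adding a pyridinyl arm to the imidazopyridine end of compound 1

This account rests on a few compounds, and the source may have more. Where it says the series, first, only, none or still open, it means among the compounds named here.

Measured compounds:
compound 1 `Cc1cc(-c2c(C)nn(C)c2C)cnc1-c1nnc(N(C)Cc2ccc3nccn3c2)o1`: 2.8
compound 2 `Cc1cc(-c2c(C)nn(C(F)F)c2C)ccc1-c1nnc(N(C)Cc2ccc3nccn3c2)o1`: 4.1

In a physicochemical assay for lipophilicity, at pH 7.4 (on this read-out lower numbers stand for lower lipophilicity and higher numbers for higher lipophilicity), compound 1 gives 2.8, the lowest of the two numbers shown, while compound 2 gives 4.1, a value beyond the scatter above it. Compound 3 `Cc1cc(-c2c(C)nn(C)c2C)cnc1-c1nnc(N(C)Cc2ccc3ncc(-c4ccc(CN(C)C)cn4)n3c2)o1` arises from compound 1 by 5-((dimethylamino)methyl)pyridin-2-yl in place of hydrogen on an aromatic carbon. Within the data shown here, no measured pair shows this step, so the expectation rests on compound 1 alone. The step is estimated to be small, within the scatter, as a number 0.20 log units lower from compound 1 to compound 3 (within the scatter). Compound 3 is therefore expected to give about 2.6 in this assay, within a range of 1.8 to 3.4.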

Compound 3, distribution coefficient: 3
Compound 3: middle estimate off by 0.40 log units, on the low side; the range from low to high includes it.
By their numbers in this assay, from the lowest: compounds 1 and 3 (each within the scatter of the next); then compound 2.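

In this assay, 5-((dimethylamino)methyl)pyridin-2-yl in place of hydrogen on this aromatic carbon gives a number 0.20 log units higher from compound 1 to compound 3 (within the scatter) and so leaves the two compounds unseparated. Among these compounds, this position of the five-membered aromatic ring therefore takes an arm of 10 heavy atoms with no distinguishable shift on this read-out, something the earlier compounds could not show. No measurement at hand offers an explanation for this result.

Open, from the compounds shown here alone, is how a plain pyridin-2-yl, a methyl or a carboxylic acid on the arm would read at this position. Also open, going by these compounds, is whether the same arm would behave alike on the core of compound 2.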